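Swapping 1-hydroxy-1-methylethyl for 1H-pyrazol-5-yl: working notes

A few compounds are considered here, and "the series" means these few. Any claim that something is new, unique, unknown or untested is made for them only; others in the source may bear on it.

Within the data shown here, in an ADME assay on MDCK cells (Canis lupus familiaris) for permeability, in the apical to basolateral direction (on this read-out higher numbers stand for higher permeability and lower numbers for lower permeability), compound 2 (`CC(C)(O)C(=O)Nc1sc(S(=O)(=O)c2ccc(F)cc2)cc1C(N)=O`) gives 4 10^-6 cm/s, the higher of the two numbers so far. Compound 1 (`CN(Cc1ccccc1)S(=O)(=O)c1cc(C(N)=O)c(NC(=O)c2ccn[nH]2)s1`) gives 0.65 10^-6 cm/s, lower beyond the usual scatter. Compound 3 (`NC(=O)c1cc(S(=O)(=O)c2ccc(F)cc2)sc1NC(=O)c1ccn[nH]1`) departs from compound 2 by 1H-pyrazol-5-yl in place of 1-hydroxy-1-methylethyl on a carbonyl carbon, with 1H-pyrazol-5-yl in place of 1-hydroxy-1-methylethyl on a carbonyl carbon. Among the measured compounds shown here, no measured pair isolates this change. Compound 1 also carries (1H-pyrazol-5-yl)carbonyl but differs elsewhere, so its 0.65 10^-6 cm/s is only a loose guide. A moderate fall is expected, estimated as a 2.7-fold lower number from compound 2 to compound 3 (0.43 log units; beyond the scatter). For compound 3 the expected value is 1.5 10^-6 cm/s, with an estimated range of 0.5 10^-6 cm/s to 4 10^-6 cm/s.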

Compound 3, apparent permeability: 0.9 10^-6 cm/s
The estimate for compound 3 lay 1.7-fold (0.22 log units) above the measured number; the range from low to high includes it.
By their numbers in this assay, from the lowest: compounds 1 and 3 (each within the scatter of the next); then compound 2.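

In this assay, among these compounds, putting 1H-pyrazol-5-yl in place of 1-hydroxy-1-methylethyl on a carbonyl carbon gives a 4.4-fold lower number from compound 2 to compound 3 (0.65 log units; beyond the scatter) and is the first clean reading of this change on one shared core. With (1H-pyrazol-5-yl)carbonyl held constant, 4-fluorophenyl in place of benzyl(methyl)amino on a sulfonyl sulfur gives a 1.4-fold higher number from compound 1 to compound 3 (0.14 log units; within the scatter) and that change stays unresolved from repeat noise on this read-out.

Open, from the compounds shown here alone, is whether an amine or a carboxylic acid on that carbonyl carbon would stand nearer compound 2 or compound 3. Nothing on hand gives a reason for the step from 1-hydroxy-1-methylethyl to 1H-pyrazol-5-yl.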